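Biaryl Replaces Aryl Ether on the Quinoline Core

A few compounds are considered here, and "the series" means these few. Any claim that something is new, unique, unknown or untested is made for them only; others in the source may bear on it.

Within the data shown here, compound 2 `COc1ccc(F)cc1CNCCCNc1ccnc2cc(Oc3ccc(Cl)cc3)ccc12` gives 317 10^-6 cm/s in an ADME assay for permeability, using PAMPA, with a stated time of 30 min, at pH 7.4 (on this read-out lower numbers stand for lower permeability and higher numbers for higher permeability), the higher of the two numbers so far; compound 1 `COc1ccc(F)cc1CNCCCNc1ccnc2cc(CCC(C)C)ccc12` gives 23 10^-6 cm/s. Among the measured compounds shown here, the one measured step, a 14-fold higher number from compound 1 to compound 2 (1.14 log units; beyond the scatter), sits at the same aromatic carbon that changes again here. Compound 3 `COc1ccc(F)cc1CNCCCNc1ccnc2cc(-c3ccc(C(F)(F)F)cc3)ccc12` carries 4-(trifluoromethyl)phenyl in place of 4-chlorophenoxy on an aromatic carbon. That step swaps one aromatic substituent for another, so the change from compound 2 to compound 3 is expected to stay small, a 1.3-fold lower number from compound 2 to compound 3 (0.10 log units; within the scatter). Compound 3 is expected to give 250 10^-6 cm/s, within 100 10^-6 cm/s to 600 10^-6 cm/s.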

Compound 3, apparent permeability in the ADME assay: 237 10^-6 cm/s
Compound 3: middle estimate off by 1.1-fold (0.02 log units), on the high side; the range from low to high includes it.
By their numbers in the ADME assay, from the lowest: compound 1; then compounds 3 and 2 (each within the scatter of the next).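

At this aromatic carbon, the ADME assay does not tell 4-(trifluoromethyl)phenyl from 4-chlorophenoxy (a 1.3-fold lower number from compound 2 to compound 3 (0.13 log units; within the scatter)), although only the latter carries an oxygen, and the large gap to isopentyl holds with this second aromatic group (a 10-fold higher number from compound 1 to compound 3 (1.01 log units; beyond the scatter)). In a physicochemical assay for acid dissociation, compound 2 gives 9.28 and compound 3 gives 9.47, which also lie within the scatter of each other. Nothing given here accounts for these results. On these data alone, it remains open whether the ADME assay would place a carboxylic acid or an amine at this carbon nearer compound 1 or nearer compounds 2 and 3.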